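The compounds below may be only part of what the source reports. "The series", "measured", "known", "first", "only" and "open" are said of these compounds alone.

Working notes on the series, read in a functional assay on HL-60 cells (Homo sapiens) for inhibition, read by CCK-8 assay, with a stated time of 48 h; on this read-out lower numbers stand for stronger inhibition and higher numbers for weaker inhibition. Compound 1 (`O=S(=O)(NCCNC(=S)Nc1cccc(Cl)c1)c1ccc(-c2ccccc2OCc2cccc(O)c2)s1`) gives 1800 nM and compound 2 (`O=C(NCCNS(=O)(=O)c1ccc(-c2ccccc2OCc2cccc(O)c2)s1)Nc1cc(Cl)cc(Cl)c1`) gives 2800 nM, with a 1.6-fold higher number from compound 1 to compound 2 (0.19 log units; within the scatter). Compound 3 (`O=[N+]([O-])c1ccc(NC(=S)NCCNS(=O)(=O)c2ccc(-c3ccccc3OCc3cccc(O)c3)s2)cc1`) gives 10800 nM, the highest number of the three. Compound 4 (`O=[N+]([O-])c1cccc(NC(=S)NCCNS(=O)(=O)c2ccc(-c3ccccc3OCc3cccc(O)c3)s2)c1`) is unmeasured and carries 3-nitrophenyl in place of 4-nitrophenyl on an amide-type nitrogen.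

For the measured compounds named here, no measured step isolates this change. The nearest evidence is a 6.0-fold higher number from compound 1 to compound 3 (0.78 log units; beyond the scatter), where 4-nitrophenyl replaces 3-chlorophenyl, and a 3.9-fold higher number from compound 2 to compound 3 (0.59 log units; beyond the scatter) is of similar size. Compound 4 keeps the 3-substitution of compound 1 but keeps the nitro group of compound 3, so it is expected to fall between them. A modest step to a lower number in this assay is expected, although a result within the scatter would not be surprising. The estimate amounts to a 2.2-fold lower number from compound 3 to compound 4 (0.33 log units; beyond the scatter), an expected partial recovery. For compound 4 the expected value is 5000 nM, with an estimated range of 1900 nM to 13000 nM.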

Compound 4, half-maximal inhibitory concentration: 11400 nM
The estimate for compound 4 lay 2.3-fold (0.36 log units) below the measured number, and the stated range covers the measured number.
By their numbers in this assay, from the lowest: compounds 1 and 2 (each within the scatter of the next); then compounds 3 and 4 (each within the scatter of the next).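

In this assay, moving the nitro group from 4-nitrophenyl to 3-nitrophenyl on the amide-type nitrogen gives no readable change (a 1.1-fold higher number from compound 3 to compound 4 (0.02 log units; within the scatter)), so the placement of nitro does not separate this pair. The step that isolates the group itself is nitro in place of chloro on an aromatic carbon (a 6.3-fold higher number from compound 1 to compound 4 (0.80 log units; beyond the scatter)), which lies beyond the scatter with the 3-substitution kept, and the gap to the carbonyl-linked dichloro compound remains of similar size (a 4.1-fold higher number from compound 2 to compound 4 (0.61 log units; beyond the scatter)). Nothing at hand explains these steps.

On these data alone, whether an amine or a carboxylic acid on the same aromatic carbon would read like nitro or like chloro remains open. A matched pair with the same aryl group that isolates thiocarbonyl against carbonyl is also missing.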